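Swapping an Ester for a Vinyl Group on a Shared Core

This account rests on a few compounds, and the source may have more. Where it says the series, first, only, none or still open, it means among the compounds named here.

Of the compounds shown here, two built on a shared core have so far been tested in a functional assay on HeLa cells (Homo sapiens) for inhibition, read by CCK-8 assay, with a stated time of 48 h; a lower number here means a stronger inhibitor, a higher number a weaker inhibitor. Compound 1, `COc1cc(-c2ccnc3cc(-c4ccc(N(C)C)cc4)nn23)cc(OC)c1OC`, gives 378 nM. Compound 2, `CCOC(=O)c1ccc(-c2cc3nccc(-c4cc(OC)c(OC)c(OC)c4)n3n2)cc1`, carries an ethoxycarbonyl group where compound 1 carries a dimethylamino group. In this assay compound 2 reaches only the limit of > 10000 nM, so no exact number is known for it. The step of an at least 26-fold higher number from compound 1 to compound 2 (1.42 log units; beyond the scatter) shows that this single exchange weakens inhibition sharply, with the reading stopping at the limit of > 10000 nM in this assay, at which 1 of the 2 values shown sits.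

Compound 3, `C=Cc1ccc(-c2cc3nccc(-c4cc(OC)c(OC)c(OC)c4)n3n2)cc1`, keeps the core of compound 2 and changes one group: vinyl in place of ethoxycarbonyl on an aromatic carbon. Among the compounds with values here, only one measured step touches this position, an at least 26-fold higher number from compound 1 to compound 2 (1.42 log units; beyond the scatter), and it concerns a different group, not vinyl, so it guides the expectation only loosely. Because compound 2 sits at the limit of > 10000 nM in this assay, at which 1 of the 2 values shown sits, any change for compound 3 can only be measured as a move toward stronger inhibition or as no measurable move. A modest step of an at least 3.3-fold lower number from compound 2 to compound 3 (0.52 log units; beyond the scatter) toward a lower number is expected, with wide uncertainty. Compound 3 is estimated at 3000 nM, within a range from 700 nM to 12000 nM.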

Compound 3, half-maximal inhibitory concentration: 882 nM
Compound 3: the middle estimate sits 3.4-fold (0.53 log units) above what was measured, within the range that was stated.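

Within the data shown here, until now, the only change seen at this position had sharply weakened inhibition, which left open whether the dimethylamino group of compound 1 was needed there. Compound 3 shows that it is not strictly required: in this assay, vinyl in place of ethoxycarbonyl gives an at least 11-fold lower number from compound 2 to compound 3 (1.05 log units; beyond the scatter), and the remaining gap to the dimethylamino compound is only a 2.3-fold higher number from compound 1 to compound 3 (0.37 log units; beyond the scatter), a modest step, though still beyond the scatter. The gain from the ester exchange is a lower bound rather than an exact size, since compound 2 stands at a limit of the assay: the limit of > 10000 nM in this assay, at which 1 of the 3 values shown sits.

The exchange replaces a larger group carrying hydrogen-bond acceptors with a smaller one carrying none, and the compounds shown cannot tell which of these differences goes with the recovered inhibition. As far as these compounds go, it also remains open how a carboxylic acid, a primary amine or an ethyl group, which would keep the carbon chain but lose the double bond, would read at this same place on the ring.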